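Swapping the sulfonyl substituent back to an aryl group

The compounds below may be only part of what the source reports. "The series", "measured", "known", "first", "only" and "open" are said of these compounds alone.

Measured so far:
- compound 1 `O=C(NS(=O)(=O)c1ccc(F)cc1)c1ccc(Nc2nc(NC3(c4ccc(Cl)cc4)CC3)nc(OCC(F)(F)F)n2)cc1`: 100%
- compound 2 `CC(C)(C)CNCCS(=O)(=O)NC(=O)c1ccc(Nc2nc(NC3(c4ccc(Cl)cc4)CC3)nc(OCC(F)(F)F)n2)cc1`: 89%

Both compounds share one core and differ only in the group on the sulfonyl sulfur. In an ADME assay on microsomes from liver (Homo sapiens) for metabolic stability, with a stated time of 10 min (a lower number here means that less of the compound is left, a higher number that more of the compound is left), compound 1 gives 100%, and in this assay compound 2 gives 89%. Among the compounds with values here, compound 2 thus stands at the lower of the two numbers; its only neighbour is compound 1, and the step of a number 11 percentage points lower from compound 1 to compound 2 (beyond the scatter) lies beyond the scatter.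

Compound 3 `Cc1ccccc1S(=O)(=O)NC(=O)c1ccc(Nc2nc(NC3(c4ccc(Cl)cc4)CC3)nc(OCC(F)(F)F)n2)cc1` has not yet been measured. The change from compound 2 is 2-methylphenyl in place of 2-(neopentylamino)ethyl on a sulfonyl sulfur. Within the data shown here, the one measured step that bears on this, a number 11 percentage points lower from compound 1 to compound 2 (beyond the scatter), shows that exchanging an aromatic ring on the sulfonyl sulfur for the 2-(neopentylamino)ethyl chain lowered the number modestly. Compound 3 carries an aromatic ring again, so the reverse is expected: an upward step of about a number 7 percentage points higher from compound 2 to compound 3 (within the scatter) in this assay, bringing compound 3 close to compound 1. Compound 3 is therefore estimated at 96%, within a range from 85% to 100%.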

Compound 3, percent of the compound remaining: 100%
For compound 3 the middle estimate is 4 percentage points below the measured one, within the range that was stated.
By their numbers in this assay, from the lowest: compound 2; then compounds 1 and 3 (each within the scatter of the next).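

In this assay, 2-methylphenyl in place of the 2-(neopentylamino)ethyl chain gives a number 11 percentage points higher from compound 2 to compound 3 (beyond the scatter), so a second aromatic ring on the sulfonyl sulfur, not only 4-fluorophenyl, goes with the higher number. Within the data shown here, the two aromatic groups show no change at the digits printed from compound 1 to compound 3 (within the scatter), which means that neither the methyl group nor the fluorine sets compound 1 and compound 3 apart in this read-out, and compound 2, the one compound with a chain in this place, is the only one that stands lower. Nothing measured here explains why the chain and the rings differ.

Compound 2 differs from the other two in both its lack of a ring and its amine nitrogen, so the compounds shown cannot tell which of these features goes with its lower number; a plain hydrocarbon chain such as neopentyl, or a ring carrying an amine, would separate the two. As far as these compounds go, compound 1 and compound 3 also both stand at the top of the scale, so any difference between aromatic groups, such as a pyridine ring in place of the phenyl ring, remains open in this read-out.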